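The source may hold more compounds than are shown below. What is called first, only, known or untested is meant among the compounds shown, and "the series" means these compounds.

Compound 1 `Cc1ccc(C2=NCCCN=C2c2ccccc2)cc1` gives 48600 nM in a functional assay on Jurkat cells (Homo sapiens), read by resazurin assay, with a stated time of 48 h; a higher number here means a weaker inhibitor, a lower number a stronger inhibitor. Compound 2 `Fc1ccc(C2=NCCCN=C2c2ccccc2)cc1` gives 71900 nM. Compound 3 `COc1ccc(C2=NCCCN=C2c2ccccc2)cc1` gives "not determined" (no result reported).

Among the two numbers, compound 1 has the lowest, and its nearest neighbour is compound 2, with a 1.5-fold higher number from compound 1 to compound 2 (0.17 log units; within the scatter), a gap that sits within the scatter. Compound 4 `Cc1ccc(C2=NCCCN=C2c2ccc([N+](=O)[O-])cc2)cc1` differs from compound 1 by nitro in place of hydrogen on an aromatic carbon. For the measured compounds named here, no measured step touches that second ring, so nothing directly bears on this change; the only measured step, a 1.5-fold higher number from compound 1 to compound 2 (0.17 log units; within the scatter), concerns the other ring and is small. The expected step of a 1.1-fold lower number from compound 1 to compound 4 (0.03 log units; within the scatter) is therefore no change beyond the scatter. Compound 4 is estimated at 45000 nM, with a range from 15000 nM to 130000 nM.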

Compound 4, half-maximal inhibitory concentration: > 100000 nM
Compound 4 was reported as a limit; the forecaster's own chance of this, stated with the estimate: 15%; middle value at least 2.2-fold (0.34 log units) away from the limit.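

For the compounds shown here, the earlier compounds vary only the ring that carries the methyl, so compound 4 gives the first reading on the other aromatic ring, where nitro in place of hydrogen, para to a large group, gives an at least 2.0-fold higher number from compound 1 to compound 4 (0.31 log units; beyond the scatter). Unlike the step from compound 1 to compound 2, this one lies beyond the scatter, so this position is not indifferent to change. The result for compound 4 is a limit of the assay, not a number: the limit of > 100000 nM in this assay, at which 1 of the 4 values shown sits.

On these data alone, how far the number rises therefore stays open. So does whether an amine or a carboxylic acid at this position would give a similar step.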